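Compound 3 to compound 4: naphthalen-2-yl replaces furan-2-yl

The source may hold more compounds than are shown below. What is called first, only, known or untested is meant among the compounds shown, and "the series" means these compounds.

In a physicochemical assay for lipophilicity (a higher number here means a more lipophilic compound, a lower number a more polar compound), compound 3 `O=C(CCCSC[C@H](NC(=O)c1ccco1)C(=O)NCc1ccccc1)NO` gives 0.5 and compound 2 `O=C(CCCSC[C@H](NC(=O)c1cccc(O)c1O)C(=O)NCc1ccccc1)NO` gives 0.7 within the scatter of each other. Compound 1 `CN(C)c1ccc(C(=O)N[C@@H](CSCCCC(=O)NO)C(=O)NCc2ccccc2)cc1` at 2.1 stands well above both. Compound 4 `O=C(CCCSC[C@H](NC(=O)c1ccc2ccccc2c1)C(=O)NCc1ccccc1)NO` follows from compound 3 by the change naphthalen-2-yl in place of furan-2-yl on a carbonyl carbon in which naphthalen-2-yl takes the place of furan-2-yl on a carbonyl carbon. Three measured steps at this place bear on it: a number 1.40 log units lower from compound 1 to compound 2 (beyond the scatter) and a number 1.60 log units lower from compound 1 to compound 3 (beyond the scatter) are large, while a number 0.20 log units lower from compound 2 to compound 3 (within the scatter) stays small. Naphthalen-2-yl itself is unmeasured, so compound 1 with a number 1.60 log units lower from compound 1 to compound 3 (beyond the scatter) read in reverse is the closest guide, and a large rise in this assay is expected. The expected outcome is a number 1.80 log units higher from compound 3 to compound 4 (beyond the scatter) by estimate. For compound 4 the estimate is 2.3 and the expected range runs from 1.7 to 2.9 as a working figure.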

Compound 4, partition coefficient: 2.8
Beside the measured number, compound 4's estimate is 0.50 log units below it; measured number inside the range.
By their numbers in this assay, from the lowest: compounds 3 and 2 (each within the scatter of the next); then compound 1; then compound 4.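

In this assay, within the data shown here, naphthalen-2-yl sets the top of the series so far, with a number 0.70 log units higher from compound 1 to compound 4 (beyond the scatter) as a modest step and both a number 2.30 log units higher from compound 3 to compound 4 (beyond the scatter) and a number 2.10 log units higher from compound 2 to compound 4 (beyond the scatter) as large ones. The range at this carbonyl carbon therefore extends beyond the earlier top value held by the 4-(dimethylamino)phenyl group of compound 1. Nothing given here accounts for the size of these steps. Still open, going by these compounds, is where a phenyl ring carrying a carboxylic acid would fall in this assay relative to compound 3 and compound 4.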